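Ester to Alcohol on the Nitrothiazole Side Chain

This account rests on a few compounds, and the source may have more. Where it says the series, first, only, none or still open, it means among the compounds named here.

Compound 1 `COc1ccc(Sc2sc(C(C)=O)nc2[N+](=O)[O-])cc1OC`: > 50000 nM
Compound 2 `CCCC(=O)OC(C)c1nc([N+](=O)[O-])c(Sc2c(Cl)cncc2Cl)s1`: 4490 nM
Compound 3 `Cc1ccc(CNC(=O)c2nc([N+](=O)[O-])c(Sc3c(Cl)cncc3Cl)s2)cc1`: 3650 nM

Of the compounds shown here, three have been measured in an assay on isolated protein for inhibition of ubiquitin carboxyl-terminal hydrolase 7 (Homo sapiens), read by fluorescence, with stated times of 30 min and 3 h; a lower number here means a stronger inhibitor, a higher number a weaker inhibitor. Compound 1 reaches only (the limit of > 50000 nM in this assay, at which 1 of the 3 values shown sits), a limit rather than a number. Compound 2 gives 4490 nM, and compound 3 gives 3650 nM; these two numbers lie within the usual scatter of each other, so neither stands apart from the other.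

Compound 4 `CC(O)c1nc([N+](=O)[O-])c(Sc2c(Cl)cncc2Cl)s1` follows from compound 2 by a single change: hydrogen in place of propylcarbonyl on an oxygen on a saturated carbon. Within the data shown here, no two measured compounds differ in just one place, so no measured step offers a reference for this cut. A step from compound 2 to compound 4 is expected to stay near the scatter, leaning toward a weaker inhibitor, that is a 1.4-fold higher number from compound 2 to compound 4 (0.16 log units; within the scatter). Compound 4 is therefore estimated at 6500 nM, between 1500 nM and 28000 nM.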

Compound 4, half-maximal inhibitory concentration: 6950 nM
The estimate for compound 4 lay 1.1-fold (0.03 log units) below the measured number; the measured number falls inside the stated range.
By their numbers in this assay, from the lowest: compounds 3, 2 and 4 (each within the scatter of the next). At a limit, above all of these: compound 1.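

In this assay, among these compounds, the step of a 1.5-fold higher number from compound 2 to compound 4 (0.19 log units; within the scatter) is the first single-place comparison on this side chain. The propylcarbonyl can leave the oxygen on the saturated carbon, turning the 1-((propylcarbonyl)oxy)ethyl into 1-hydroxyethyl, without the number moving beyond the scatter, so the ester is not needed to keep activity at this level. No measurement given here bears on why this step stays so small. The compounds shown leave open whether an amine, a carboxylic acid or a longer chain at this oxygen-bearing carbon would move the number beyond the scatter in either direction.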